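Methoxy addition in a series silent on cytotoxicity

A few compounds are considered here, and "the series" means these few. Any claim that something is new, unique, unknown or untested is made for them only; others in the source may bear on it.

Compound 1 `COc1ccc(CNc2ncnc3c2ncn3C2CCCCO2)cc1` is the reference point; compound 2 `COc1ccc(CNc2ncnc3c2ncn3C2CCCCO2)cc1OC` and compound 3 `COc1ccc(CNc2ncnc3c2ncn3C2CCCO2)cc1` each differ from it in one place, and compound 4 `COc1ccc(CNc2ncnc3c2ncn3C2CCCO2)c(OC)c1` is still to be measured. In an ADME assay on MCF7 cells (Homo sapiens) for cytotoxicity, with a stated time of 72 h (on this read-out lower numbers stand for stronger inhibition and higher numbers for weaker inhibition), compound 1 gives only a limit of the assay, > 100000 nM. Compound 2 also gives only a limit in this assay, > 100000 nM. Compound 3 likewise sits at a limit, > 100000 nM. From these limits follow a step that the two limits leave unreadable from compound 1 to compound 2 and a step that the two limits leave unreadable from compound 1 to compound 3. The two cores differ in that (oxolan-2-yl in place of oxan-2-yl on an aromatic nitrogen). The change from compound 3 to compound 4 is methoxy in place of hydrogen on an aromatic carbon; the same kind of change is made from compound 1 to compound 2, (methoxy in place of hydrogen on an aromatic carbon), where the entering group is ortho to a methoxy group and meta to a large group, whereas in compound 4 it is ortho to a large group and meta to a methoxy group. All measured values sit at the limit of > 100000 nM in this assay, at which 3 of the 3 values shown sit. The expected step in this assay is a step that the limit leaves unreadable from compound 3 to compound 4, resting on compound 3 sitting at the limit of > 100000 nM in this assay, at which 3 of the 3 values shown sit, and on a step that the two limits leave unreadable from compound 1 to compound 2. Compound 4 is expected at 150000 nM, with a range from 50000 nM to 500000 nM.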

Compound 4, half-maximal inhibitory concentration: > 100000 nM
Compound 4: a limit, no number; the forecaster's own chance of this, stated with the estimate: 85%; the middle value does not contradict the limit.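

No step can be read between compound 3 and compound 4, as both give only a limit in this assay, and the same holds for all four compounds: the limit of > 100000 nM in this assay, at which 4 of the 4 values shown sit.

The compounds shown leave open whether methoxy in place of hydrogen, at either place, or oxolan-2-yl in place of oxan-2-yl changes the read-out in this assay at all.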